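Moving the chlorine on a piperazine-linked phenyl ring

This account rests on a few compounds, and the source may have more. Where it says the series, first, only, none or still open, it means among the compounds named here.

Measured compounds:
- Compound 1 `COc1ccccc1N1CCN(CC(=O)N2CCN(c3nnc(-c4ccc(C)cc4)c(-c4ccc(C)cc4)n3)CC2)CC1`: 59400 nM
- Compound 2 `Cc1ccc(-c2nnc(N3CCN(C(=O)CN4CCN(c5cccc(Cl)c5)CC4)CC3)nc2-c2ccc(C)cc2)cc1`: 797000 nM
- Compound 3 `O=C(CN1CCN(c2ccccc2Cl)CC1)N1CCN(c2nnc(-c3ccc(Cl)cc3)c(-c3ccc(Cl)cc3)n2)CC1`: 396000 nM

In a functional assay on MCF7 cells (Homo sapiens) for cytotoxicity, read by MTT assay, with a stated time of 24 h (on this read-out lower numbers stand for stronger inhibition and higher numbers for weaker inhibition), compound 3 stands second highest of the three numbers. Its nearest neighbour is compound 2, whose number is higher but within the usual scatter, so the two cannot be told apart; compound 1 sits well below it, beyond the scatter. Compound 4 `O=C(CN1CCN(c2cccc(Cl)c2)CC1)N1CCN(c2nnc(-c3ccc(Cl)cc3)c(-c3ccc(Cl)cc3)n2)CC1` is the unmeasured partner of compound 3. The change is 3-chlorophenyl in place of 2-chlorophenyl on an amine nitrogen in a ring: the same atoms, joined differently, so only the position of the chlorine on that phenyl ring moves.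

Among the compounds with values here, no measured pair shows this exact change. Within the data shown here, the only measured step that touches the same ring position is a 13-fold higher number from compound 1 to compound 2 (1.13 log units; beyond the scatter), where the entering group was also 3-chlorophenyl, though the leaving group there was 2-methoxyphenyl rather than 2-chlorophenyl, so it bears on compound 4 only loosely. Compound 2, the one measured compound carrying 3-chlorophenyl, also has the highest number shown, but it differs from compound 3 in more than one place.

On this thin evidence a somewhat higher number is expected for compound 4, likely a 1.5-fold higher number from compound 3 to compound 4 (0.18 log units; within the scatter) and possibly within the scatter. Compound 4 is therefore estimated at 600000 nM, with a plausible range from 200000 nM to 1800000 nM.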

Compound 4, half-maximal inhibitory concentration: > 803000 nM
Compound 4: only a limit was reported; the forecaster's own chance of this, stated with the estimate: 10%; at least 1.3-fold (0.12 log units) between middle value and limit.
By their numbers in this assay, from the lowest: compound 1; then compounds 3 and 2 (each within the scatter of the next). At a limit, above all of these: compound 4.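

Within the data shown here, this pair gives the first clean look at this position: 3-chlorophenyl replaces 2-chlorophenyl on an amine nitrogen in a ring, so the chlorine moves while the rest of the molecule stays the same, whereas the earlier step at this position also exchanged a 2-methoxyphenyl group for the chlorinated ring. In this assay compound 4 gave only a limit and not an exact number: the limit of > 803000 nM in this assay, at which 1 of the 4 values shown sits. From the compounds shown here alone, the change is therefore recorded as an at least 2.0-fold higher number from compound 3 to compound 4 (0.30 log units; that floor lies within the scatter), which gives a floor and not a size, so the true gap stays unknown and the floor alone does not separate the two compounds.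

The compounds shown leave open whether moving the chlorine would read the same way on the core of compound 1, which carries methyl groups on its outer phenyl rings where compound 4 carries chlorine. They also leave open how a phenyl ring bearing an amine or a carboxylic acid in place of the chlorine would behave in this assay at this same place on the ring nitrogen.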